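Ethoxy for Fluoro in a Mitochondrial Activation Series

The compounds below may be only part of what the source reports. "The series", "measured", "known", "first", "only" and "open" are said of these compounds alone.

Compound 1 `FC(F)(F)Oc1ccc(Nc2nc3nonc3nc2Nc2ccc(OC(F)(F)F)c(Br)c2)cc1Br`: 2200 nM
Compound 2 `Fc1ccc(Nc2nc3nonc3nc2Nc2ccccc2F)cc1`: 2300 nM

Of the compounds shown here, two have been tested in an assay on mitochondria from L6 cells (Rattus norvegicus) for activation, with a stated time of 90 min; on this read-out higher numbers stand for an effect only at larger amounts of compound and lower numbers for an effect already at smaller amounts. Compound 1 gives 2200 nM and compound 2 gives 2300 nM. These two values lie within the scatter of each other, so neither can be set above the other; they share a common core and differ only in the groups on the two outer rings.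

Compound 3 `CCOc1ccc(Nc2nc3nonc3nc2Nc2ccccc2F)cc1` has not yet been measured. It differs from compound 2 in a single place: ethoxy in place of fluoro on an aromatic carbon. Going by the values given here, no measured pair shows this same exchange, so there is no direct guide to its effect. Among the compounds with values here, with only two values in hand, both close together, the expected step is a 1.1-fold higher number from compound 2 to compound 3 (0.04 log units; within the scatter), that is, no change beyond the scatter. The estimated value for compound 3 is therefore 2500 nM, with a range from 800 nM to 8000 nM.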

Compound 3, half-maximal effective concentration: 3800 nM
Beside the measured number, compound 3's estimate is 1.5-fold (0.18 log units) below it; the measured number falls inside the stated range.
By their numbers in this assay, from the lowest: compounds 1, 2 and 3 (each within the scatter of the next).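

Going by these compounds alone, putting ethoxy in place of fluoro, para to a large group, gives a 1.7-fold higher number from compound 2 to compound 3 (0.22 log units; within the scatter) in this assay, a first reading of a single exchange at this position. The position therefore takes ethoxy, a larger group that brings a hydrogen-bond acceptor, with no change that can be told apart from the scatter. Compound 1 and compound 2 differ in several places, so that pair could not show what this one position does on its own.

No measurement at hand explains this result. On these data alone, it remains open whether an amine, a carboxylic acid or a longer chain such as butoxy at this position would move the number beyond the scatter, and whether ethoxy would behave the same way with other groups on the second outer ring.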